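A Carboxyphenyl Swap from Compound 2 to Compound 3

The compounds below may be only part of what the source reports. "The series", "measured", "known", "first", "only" and "open" are said of these compounds alone.

In an ADME assay on a cell-free system (plasma, Rattus norvegicus) for metabolic stability, read by LC-MS, with a stated time of 1 h, at 37 degrees C, tested at 100 uM (a higher number here means that more of the compound is left, a lower number that less of the compound is left), compound 1 `O=C1c2ccc(OCc3cccc(-c4ccccc4)c3)cc2CN1C1CCCC1` gives 95%, and compound 2 `COc1ccc(C(=O)O)cc1-c1cccc(COc2ccc3c(c2)CN(C2CCCC2)C3=O)c1` gives 100%. Within the data shown here, compound 2 therefore stands level with compound 1, the only other measured compound. Compound 3 `O=C(O)c1cc(-c2cccc(COc3ccc4c(c3)CN(C3CCCC3)C4=O)c2)ccc1O` has 3-carboxy-4-hydroxyphenyl in place of 5-carboxy-2-methoxyphenyl on an aromatic carbon. Among the measured compounds shown here, no measured compound carries the entering group, so the data offer no direct test of it. For the measured compounds named here, only one measured step bears on the change, the one that introduced the leaving group in place of phenyl. No shift beyond the scatter is expected in this assay because a number 5 percentage points higher from compound 1 to compound 2 (within the scatter) was the whole of that replacement's effect. The expected step is a number 3 percentage points lower from compound 2 to compound 3 (within the scatter). For compound 3 the estimated value is 97%, with an expected range of 87% to 105%.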

Compound 3, percent of the compound remaining: 98%
The estimate for compound 3 lay 1 percentage points below the measured number; the measured number falls inside the stated range.
By their numbers in this assay, from the lowest: compounds 1, 3 and 2 (each within the scatter of the next).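

In this assay, 3-carboxy-4-hydroxyphenyl in place of 5-carboxy-2-methoxyphenyl gives a number 2 percentage points lower from compound 2 to compound 3 (within the scatter) on this aromatic carbon, so a second carboxyphenyl group with a different ring pattern also leaves the reading level. Set against the plain phenyl of the first compound, the same group gives a number 3 percentage points higher from compound 1 to compound 3 (within the scatter) in the same assay, and the three groups seen at this place cannot be told apart by this read-out. No supporting measurement is available to explain this level reading.

From the compounds shown here alone, whether a methyl ester in place of the carboxylic acid, or an amine on this ring, would also stay within the scatter remains open. Also open, going by these compounds, is whether changes elsewhere on the shared core would move the number in this assay.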